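A few compounds are considered here, and "the series" means these few. Any claim that something is new, unique, unknown or untested is made for them only; others in the source may bear on it.

In a functional assay on HCT-116 cells (Homo sapiens) for antiproliferative activity, read by MTT assay, with a stated time of 72 h (on this read-out higher numbers stand for weaker inhibition and lower numbers for stronger inhibition), three compounds have been measured so far. Compound 1 `Oc1ccc(Cl)cc1/C=N/c1ccc(-c2nc3ccccc3o2)c(O)c1` gives 20100 nM. Compound 2 `Nc1ccc(SCC(=O)Nc2ccc3nc(NC(=O)c4ccc(C(F)(F)F)cc4)sc3c2)cc1` gives 100 nM, the lower of the two actual numbers, and its gap to compound 1 lies well beyond the scatter of repeated measurements. Compound 3 `COc1cc(CNC(C)(C)CO)ccc1OCC(=O)Nc1ccc(C)cc1` gives > 100000 nM, which is a limit of the assay and not a number.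

The compound now awaiting measurement, compound 4 `O=C(CSc1ccc(Cl)cc1)Nc1ccc2nc(NC(=O)c3ccc(C(F)(F)F)cc3)sc2c1`, matches compound 2 except at one place. It has chloro in place of amino on an aromatic carbon, para to a large group, so that 4-aminophenyl becomes 4-chlorophenyl (chloro in place of amino on an aromatic carbon). Going by the values given here, no pair of measured compounds differs in one place, so this assay offers no direct precedent for this change, and compounds 1 and 3 differ too widely from compound 2 to serve as a guide. The expectation therefore starts from compound 2 at 100 nM, whose remaining structure is kept intact, and allows only a modest shift towards weaker inhibition that may not exceed the scatter. The expected change is a 2.0-fold higher number from compound 2 to compound 4 (0.30 log units; within the scatter). For compound 4 the estimated value is 200 nM, with an expected range from 40 nM to 1500 nM.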

Compound 4, half-maximal inhibitory concentration: 930 nM
For compound 4 the middle estimate is 4.7-fold (0.67 log units) below the measured one, and the stated range covers the measured number.
By their numbers in this assay, from the lowest: compound 2; then compound 4; then compound 1. At a limit, above all of these: compound 3.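

In this assay, going by these compounds alone, this position on the 4-aminophenyl ring responds clearly to a single-atom exchange: chloro in place of amino on an aromatic carbon gives a 9.3-fold higher number from compound 2 to compound 4 (0.97 log units; beyond the scatter), the only step so far between compounds that differ in one place. The exchange replaces a group counted with one hydrogen-bond donor and one hydrogen-bond acceptor by one counted with neither, and here it goes with weaker inhibition, but a single pair cannot tell whether that count or some other difference between the two groups accounts for the step. Nothing measured in this series gives a cause for the step.

Whether the amino group is specifically favoured at this position remains open, as the compounds shown include no other group there, such as hydroxyl, methoxy, fluoro or a dimethylamino group, and no unsubstituted phenyl ring for reference. Within the data shown here, also open is whether the exchange would give a step of similar size with a longer chain in place of the sulfanylmethyl link, or on a core other than the one shared by compound 2 and compound 4.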